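Swapping the amide aryl group on a shared aminoquinoline-derived core

The source may hold more compounds than are shown below. What is called first, only, known or untested is meant among the compounds shown, and "the series" means these compounds.

Measured compounds:
- compound 1, `Nc1cccc2c(-c3cccc(NC(=O)c4ccc(Cl)c(C(F)(F)F)c4)c3)ccnc12`: 2800 nM
- compound 2, `Nc1cccc2c(-c3cccc(NC(=O)c4ccc5c(c4)OCCO5)c3)ccnc12`: 11400 nM

Both compounds were tested in a functional assay on UACC-257 cells (Homo sapiens) for antiproliferative activity, read by sulforhodamine B assay, with a stated time of 48 h; on this read-out lower numbers stand for stronger inhibition and higher numbers for weaker inhibition. On these two numbers compound 2 stands highest: compound 1 sits at 2800 nM, while compound 2 sits at 11400 nM, a gap that lies beyond the usual scatter. The two differ only in the group on the carbonyl carbon of the amide.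

Among the compounds with values here, compound 3, `Nc1cccc2c(-c3cccc(NC(=O)c4nccs4)c3)ccnc12`, keeps the core and the amide of compound 2 and changes only that group: 1,3-thiazol-2-yl in place of 2,3-dihydro-1,4-benzodioxin-6-yl on a carbonyl carbon. Within the data shown here, no measured pair shows the effect of this exact swap, so the direction of the step is open. Among the measured compounds shown here, since the one related change seen here moves the number well beyond the scatter, a step of similar size in either direction is plausible; on balance a weaker or roughly unchanged value is expected for compound 3, at 15000 nM within 4000 nM to 50000 nM, meaning an expected step of a 1.3-fold higher number from compound 2 to compound 3 (0.12 log units; within the scatter).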

Compound 3, half-maximal inhibitory concentration: 24300 nM
Beside the measured number, compound 3's estimate is 1.6-fold (0.21 log units) below it; low and high end bracket the measured number.
By their numbers in this assay, from the lowest: compound 1; then compound 2; then compound 3.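

In this assay, the group on the carbonyl carbon of the amide now has a step of its own: replacing 2,3-dihydro-1,4-benzodioxin-6-yl with 1,3-thiazol-2-yl gives a 2.1-fold higher number from compound 2 to compound 3 (0.33 log units; beyond the scatter), a modest loss of inhibition. Together with compound 1, this shows that three different groups at this one place give three separate numbers, with compound 3 the highest of the set. Nothing measured here explains why the number rises with this swap.

The swap changes ring size and ring atoms at once, so the part of the change that matters cannot be separated. As far as these compounds go, how a plain phenyl ring, a pyridin-2-yl ring or a non-aromatic group such as cyclohexyl would behave on this carbonyl carbon remains open.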